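Adding a second chloro to the cinnamoyl ring of compound 3

The source may hold more compounds than are shown below. What is called first, only, known or untested is meant among the compounds shown, and "the series" means these compounds.

Measured so far in a functional assay on the whole organism (strain Wistar) for inhibition, with Rattus norvegicus as the target, read by paw edema, with a stated time of 3 h, at a dose of 20 mg/kg by the oral route; a higher number here means more inhibition at the dose given (going by the name of the read-out), a lower number less inhibition:
compound 1 `COc1ccc(N2COc3ccc(C(=O)/C=C/c4ccc(Cl)cc4Cl)cc3C2)cc1`, 74.9%
compound 2 `COc1ccc(/C=C/C(=O)c2ccc3c(c2)CN(c2ccc(C)cc2)CO3)cc1`, 70.4%
compound 3 `Cc1ccc(N2COc3ccc(C(=O)/C=C/c4ccc(Cl)cc4)cc3C2)cc1`, 63.4%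

Compound 3 has the lowest of the three numbers; compound 2 stands within the scatter of it, compound 1 beyond. Compound 4 `Cc1ccc(N2COc3ccc(C(=O)/C=C/c4ccc(Cl)cc4Cl)cc3C2)cc1` differs from compound 3 in one place: chloro in place of hydrogen on an aromatic carbon. Among the measured compounds shown here, no measured step covers this exact change. The only step shown, a number 7 percentage points lower from compound 2 to compound 3 (within the scatter), concerns a different swap and lies within the scatter. Compound 1 also carries the 2,4-dichlorophenyl group and gives 74.9%, though it differs from compound 4 elsewhere, so it is only a loose pointer. The step expected from compound 3 to compound 4 in this assay is therefore estimated small, a number 6.6 percentage points higher from compound 3 to compound 4 (within the scatter), if any. Compound 4 is expected to give 70%, estimated between 58% and 82%.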

Compound 4, a percentage reported as inhibition, in the whole organism at one dose (the size of the read-out at that dose, not a potency): 71.9%
The estimate for compound 4 lay 1.9 percentage points below the measured number; low and high end bracket the measured number.
By their numbers in this assay, from the lowest: compounds 3, 2, 4 and 1 (each within the scatter of the next, the first and the last beyond it).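

In this assay, going from 4-chlorophenyl to 2,4-dichlorophenyl gives a number 8.5 percentage points higher from compound 3 to compound 4 (within the scatter) and so shows that this ring position, ortho to a large group, accepts a chloro without a change beyond the scatter. With the 2,4-dichlorophenyl group kept, methyl in place of methoxy gives a number 3 percentage points lower from compound 1 to compound 4 (within the scatter) and leaves that end of the molecule equally unresolved, while changing the aryl group and the chloro pattern together gives a number 1.5 percentage points higher from compound 2 to compound 4 (within the scatter) as well. Nothing available here explains these numbers. On these data alone, whether an amine or a fluoro at this same position would separate from chloro remains open.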